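This account rests on a few compounds, and the source may have more. Where it says the series, first, only, none or still open, it means among the compounds named here.

Measured compounds and their values in a functional assay on the whole organism (B cells) with Mus musculus as the target; a lower number here means a smaller maximal response, a higher number a larger maximal response:
compound 1 `C=CCn1c(=O)n(CCCCO)c2nc(N)nc(O)c21` — 12%
compound 2 `NCC(O)Cn1c(=O)n(C2OC(CO)[C@@H](O)[C@H]2O)c2nc(N)nc(O)c21` — 110%
compound 3 `CCCn1c(=O)n(C2CCC(CO)O2)c2nc(NC(=O)C(C)(C)C)nc(O)c21` — 19%

Compound 2 holds the highest number of the three in this assay. Its nearest neighbour is compound 3, whose value stands lower by a gap beyond the scatter; compound 1 stands furthest from it, again beyond the scatter. Among the compounds with values here, no pair of these three differs in one place only, so no single step between measured compounds is at hand.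

Compound 4 `COc1ccc(Cn2c(=O)n(C3OC(CO)[C@@H](O)[C@H]3O)c3nc(N)nc(O)c32)cc1` is not yet measured. Against compound 2 the change is 4-methoxyphenyl in place of 2-amino-1-hydroxyethyl on a saturated chain carbon bound to an aromatic nitrogen. The shared core and the sugar attached to the ring nitrogen of compound 2 are retained. The chain that leaves carries two hydrogen-bond donors and two acceptors; what enters carries no donor and one acceptor, together with an aromatic ring.

Within the data shown here, with no one-place step among the measured compounds, the direction can only be guessed. Since the high response of compound 2 at 110% stands alone against the low numbers of compound 1 and compound 3, the step is expected to lower the response by an amount beyond the scatter, estimated as a number 50 percentage points lower from compound 2 to compound 4 (beyond the scatter). Compound 4 is accordingly expected to give about 60% in this assay, within a range from 20% to 110%.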

Compound 4, largest response reached (reported as maximal response), in percent of the reference or control that the assay uses: 44%
The estimate for compound 4 lay 16 percentage points above the measured number; measured number inside the range.
By their numbers in this assay, from the lowest: compounds 1 and 3 (each within the scatter of the next); then compound 4; then compound 2.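

Working notes: this is the first one-place step in the series and shows that the group on a saturated chain carbon bound to an aromatic nitrogen matters in this assay. With the shared core and the sugar retained, 4-methoxyphenyl in place of 2-amino-1-hydroxyethyl gives a large drop, a number 66 percentage points lower from compound 2 to compound 4 (beyond the scatter), yet compound 4 still reaches 44%, so this change lowers the maximal response without a printed drop to the level of the other low numbers being implied. Nothing measured here accounts for the size of this step.

Within the data shown here, the change removes the amine and the hydroxyl and adds an aromatic ring with its methoxy group in one move, so the single step cannot assign the drop to any one of these. From the compounds shown here alone, a plain benzyl, a 3-aminopropyl chain, a 3-hydroxypropyl chain or a chain ending in a carboxylic acid at this place would be needed to separate these parts, and how such groups would behave in this assay remains open.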